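The compounds below may be only part of what the source reports. "The series", "measured", "known", "first", "only" and "open" are said of these compounds alone.

Measured so far: compound 1 `Cc1ccc(N2CCN(C(=O)Nc3ccc(OC(F)(F)F)cc3)CC2)nn1` with > 10000 nM; compound 2 `CC(C)c1ccc(NC(=O)N2CCN(c3nncc4ccccc34)CC2)cc1` with > 10000 nM.

In an assay on HEK293 cells for inhibition of transient receptor potential cation channel subfamily V member 1 (Homo sapiens), read by FLIPR, at pH 5.5 (a lower number here means a stronger inhibitor, a higher number a weaker inhibitor), compound 1 gives > 10000 nM, which is a limit of the assay and not a number. In this assay compound 2 likewise gives > 10000 nM, again a limit rather than a measured number. For the measured compounds named here, compound 2 therefore stands at the limit of > 10000 nM in this assay, at which 2 of the 2 values shown sit, so its position cannot be placed more finely than that, and the pair gives no measured step to work from.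

Compound 3 `O=C(Nc1ccc(OC(F)(F)F)cc1)N1CCN(c2nncc3ccccc23)CC1` differs from compound 2 in one place: trifluoromethoxy in place of isopropyl on an aromatic carbon. Going by the values given here, as no step between measured compounds is known, there is no basis for expecting a shift beyond the scatter in either direction; compound 2 sits at a limit, and compound 3 is estimated to stay close to it, with the step from compound 2 to compound 3 expected as a step that the limit leaves unreadable from compound 2 to compound 3. The value expected for compound 3 is 15000 nM, within 3000 nM to 60000 nM.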

Compound 3, half-maximal inhibitory concentration: > 10000 nM
Compound 3: no number, only a limit; the forecaster's own chance of this, stated with the estimate: 70%; the middle value does not contradict the limit.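

In this assay compound 3 gives > 10000 nM, a limit and not a number, so the steps to compound 3 from compound 1 and compound 2 cannot be read: the limit of > 10000 nM in this assay, at which 3 of the 3 values shown sit. The compounds shown leave open whether trifluoromethoxy in place of isopropyl changes inhibition at all.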